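Benzyloxy Ring Substitution and Cell Growth Inhibition

The source may hold more compounds than are shown below. What is called first, only, known or untested is meant among the compounds shown, and "the series" means these compounds.

Compound 1, `Cc1ccc(NC(=S)NC(=O)c2ccc(OCc3ccccc3)cc2)cc1-c1nc2ccccc2[nH]1`, in a functional assay on SW-620 cells (Homo sapiens) for inhibition, read by MTT assay, with a stated time of 48 h (on this read-out higher numbers stand for weaker inhibition and lower numbers for stronger inhibition), gives 67100 nM.
Compound 2, `Cc1ccc(NC(=S)NC(=O)c2ccc(OCc3ccc(C(F)(F)F)cc3)cc2)cc1-c1nc2ccccc2[nH]1`, in this assay gives 72400 nM.
Compound 3, `Cc1ccc(NC(=S)NC(=O)c2ccc(OCc3cccc(Cl)c3Cl)cc2)cc1-c1nc2ccccc2[nH]1`, in this assay gives only a limit of the assay, > 100000 nM.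

For the measured compounds named here, compound 3 therefore stands at the edge of what this assay reports, as the sole compound among the three that sits at the limit (the limit of > 100000 nM in this assay, at which 1 of the 3 values shown sits). Compound 4, `Cc1ccc(NC(=S)NC(=O)c2ccc(OCc3ccc(Cl)c(Cl)c3)cc2)cc1-c1nc2ccccc2[nH]1`, differs from it in one place: 3,4-dichlorophenyl in place of 2,3-dichlorophenyl on a saturated chain carbon bound to an oxygen on an aromatic ring.

Going by the values given here, three measured steps bear on this change, all of them on the same benzyloxy ring. From compound 1 to compound 2 the step was a 1.1-fold higher number from compound 1 to compound 2 (0.03 log units; within the scatter). From compound 1 to compound 3 it was an at least 1.4-fold higher number from compound 1 to compound 3 (0.17 log units; that floor lies within the scatter), and from compound 2 to compound 3 an at least 1.3-fold higher number from compound 2 to compound 3 (0.14 log units; that floor lies within the scatter). None of these lies beyond the scatter, so no step beyond the scatter is expected from compound 3 to compound 4 in this assay, and the expected step is a number no higher from compound 3 to compound 4 (the limit leaves the size open). Compound 4 is estimated at 100000 nM, within 50000 nM to 300000 nM, with a fair chance that the assay again reports only a limit.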

Compound 4, half-maximal inhibitory concentration: 30700 nM
For compound 4 the middle estimate is 3.3-fold (0.51 log units) above the measured one; the measured number lies below the stated range.
By their numbers in this assay, from the lowest: compound 4; then compounds 1 and 2 (each within the scatter of the next). At a limit, above all of these: compound 3.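

Rearranging the two chlorines on the benzyl ring changes the result in this assay, although the atoms stay the same: the change from 2,3-dichlorophenyl to 3,4-dichlorophenyl gives an at least 3.2-fold lower number from compound 3 to compound 4 (0.51 log units; beyond the scatter). For the compounds shown here, the 3,4-dichlorophenyl group also separates compound 4 from the earlier rings, with a 2.4-fold lower number from compound 2 to compound 4 (0.37 log units; beyond the scatter) and a 2.2-fold lower number from compound 1 to compound 4 (0.34 log units; beyond the scatter), whereas no earlier step on this ring lay beyond the scatter. The first of these steps remains a floor, as compound 3 gives only a limit of the assay: the limit of > 100000 nM in this assay, at which 1 of the 4 values shown sits.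

The compounds shown leave open whether a single chlorine, or a bromine or a methoxy group in its place, would behave like the 3,4-dichlorophenyl group. They also leave open whether this change would carry the same step with an ethyl group in place of the methyl group on the shared core.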